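A few compounds are considered here, and "the series" means these few. Any claim that something is new, unique, unknown or untested is made for them only; others in the source may bear on it.

Working notes on the series. In a functional assay on J774 cells (Mus musculus) for cytotoxicity (on this read-out lower numbers stand for stronger inhibition and higher numbers for weaker inhibition), compound 1 `CCCN(CCC)c1c([N+](=O)[O-])cc(S(=O)(=O)Nc2ccc(C)cc2)cc1[N+](=O)[O-]` gives 11000 nM and compound 2 `CCCN(CCC)c1c([N+](=O)[O-])cc(S(=O)(=O)Nc2ccc(Cl)cc2)cc1[N+](=O)[O-]` gives 10000 nM. Among the compounds with values here, compound 2 thus sits within the scatter of compound 1, the only other measured compound, and the two values cannot be told apart.

The next structure is compound 3 `CCCN(CCC)c1c([N+](=O)[O-])cc(S(=O)(=O)Nc2cccc(OC)c2)cc1[N+](=O)[O-]`, with 3-methoxyphenyl in place of 4-chlorophenyl on a sulfonamide nitrogen.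

Within the data shown here, one measured step bears on this, a 1.1-fold lower number from compound 1 to compound 2 (0.04 log units; within the scatter), which is chloro in place of methyl on an aromatic carbon. It concerns the same aryl group and lies within the scatter. Among the measured compounds shown here, it is thin support, since it rests on a single pair and no measured compound carries a methoxy group. The data therefore give no direction, and no step beyond the scatter is expected in this assay. The step expected from this estimate is a 1.1-fold higher number from compound 2 to compound 3 (0.04 log units; within the scatter). For compound 3 the estimated value is 11000 nM, with an expected range from 4500 nM to 25000 nM.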

Compound 3, half-maximal inhibitory concentration: 25000 nM
Compound 3: the middle estimate sits 2.3-fold (0.36 log units) below what was measured; low and high end bracket the measured number.
By their numbers in this assay, from the lowest: compounds 2 and 1 (each within the scatter of the next); then compound 3.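

With the aryl group on the sulfonamide nitrogen changed to 3-methoxyphenyl, this assay gives the first differences beyond the scatter in the series: a 2.5-fold higher number from compound 2 to compound 3 (0.40 log units; beyond the scatter) and a 2.3-fold higher number from compound 1 to compound 3 (0.36 log units; beyond the scatter). The read-out at this position therefore does respond to the identity of the aryl group, even though the chloro and methyl pair, compound 1 and compound 2, could not be told apart, and both new steps point the same way towards weaker inhibition, though each is only modest. No measured information accounts for this shift, so the steps stand as bare observations.

The change from 4-chlorophenyl to 3-methoxyphenyl alters both the substituent and the number in the group's name, and these compounds leave open which of the two goes with the higher number in this assay. Also open, from the compounds shown here alone, is how an amine, a carboxylic acid or a longer alkoxy chain on the aryl group would read, and whether any replacement here gives a number lower than those of compound 1 and compound 2.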